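A few compounds are considered here, and "the series" means these few. Any claim that something is new, unique, unknown or untested is made for them only; others in the source may bear on it.

Of the compounds shown here, three have been measured in a functional assay on SN12C cells (Homo sapiens) for inhibition, read by sulforhodamine B assay, with a stated time of 48 h; a lower number here means a stronger inhibitor of growth, a higher number a weaker inhibitor of growth. Compound 1 `COc1ccc(-c2[nH]c3ccc(OC)cc3c2/C=C(\C#N)S(=O)(=O)c2ccccc2)cc1` gives 2300 nM, the second highest of the three numbers. Compound 2 `CC(=O)/C(=C\c1c(-c2ccccc2)[nH]c2ccccc12)S(=O)(=O)c1ccccc1` gives 1900 nM, which sits within the scatter of compound 1, so the two cannot be told apart. Compound 3 `COc1ccc(-c2[nH]c3ccc(OC)cc3c2C=C(C#N)C#N)cc1` gives 15900 nM, a number well beyond the scatter above that of compound 1. Compound 4 `COc1ccc(-c2[nH]c3ccccc3c2/C=C(\C#N)S(=O)(=O)c2ccccc2)cc1` remains unmeasured; set against compound 1 it differs in one place: hydrogen in place of methoxy on an aromatic carbon. Among the measured compounds shown here, no measured pair shows a change of this kind, so the expected step in this assay is small, probably none beyond the scatter, with a slight lean toward a higher number, giving an expected 1.1-fold higher number from compound 1 to compound 4 (0.04 log units; within the scatter). Compound 4 is therefore expected to give about 2500 nM, within a range from 900 nM to 7000 nM.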

Compound 4, concentration for 50% growth inhibition: 1500 nM
The estimate for compound 4 lay 1.7-fold (0.22 log units) above the measured number, and the stated range covers the measured number.
By their numbers in this assay, from the lowest: compounds 4, 2 and 1 (each within the scatter of the next); then compound 3.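

In this assay, hydrogen in place of methoxy on this aromatic carbon gives a 1.5-fold lower number from compound 1 to compound 4 (0.19 log units; within the scatter), a step within the scatter. This first comparison at this position therefore shows that the methoxy can be lost without a change that can be told apart from the scatter, at least in this pair. No evidence at hand accounts for the size of this step.

The compounds shown leave open whether an amine, a carboxylic acid or a longer alkoxy chain on this carbon would move the number beyond the scatter. They also leave open whether the same change would give a similar step in compound 3.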